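Ring Swap on the Ester Chain: Compound 3 to Compound 4

The source may report more compounds than this note shows. Statements on the series, on what has been measured and on what is new or still open speak of the compounds shown alone.

Three compounds share one core and differ only in the group on the carbonyl carbon. In an assay on membranes from HEK293 cells for displacement of a labelled ligand from adenosine receptor A2b (Homo sapiens), read by scintillation counting, with a stated time of 30 min (a lower number here means a stronger inhibitor, a higher number a weaker inhibitor), compound 1 `CC1=C(C(=O)CC(C)C)C(c2ccsc2)NC(=O)N1` gives 1000 nM, compound 2 `CC1=C(C(=O)OC2CCCC2)C(c2ccsc2)NC(=O)N1` gives 659 nM, and compound 3 `CC1=C(C(=O)OCC2CC2)C(c2ccsc2)NC(=O)N1` gives 724 nM. The gaps are small on both sides, a 1.1-fold higher number from compound 2 to compound 3 (0.04 log units; within the scatter) and a 1.4-fold lower number from compound 1 to compound 3 (0.14 log units; within the scatter), so compound 3 stands within the scatter of both companions. Compound 4 `CC1=C(C(=O)OCC2CCC2)C(c2ccsc2)NC(=O)N1` differs from compound 3 by cyclobutyl in place of cyclopropyl on a saturated chain carbon bound to an oxygen next to a carbonyl group. The most relevant measured step is a 1.1-fold higher number from compound 2 to compound 3 (0.04 log units; within the scatter), where one ring was exchanged for another at the same place and the number barely moved, and a 1.5-fold lower number from compound 1 to compound 2 (0.18 log units; within the scatter) was likewise small. A further ring change of this kind is therefore expected to give no step beyond the scatter, which for compound 4 means a 1.0-fold lower number from compound 3 to compound 4 (0.01 log units; within the scatter). Compound 4 is estimated at 700 nM, with a range from 350 nM to 1400 nM.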

Compound 4, inhibition constant: 1040 nM
The estimate for compound 4 lay 1.5-fold (0.17 log units) below the measured number; low and high end bracket the measured number.
By their numbers in this assay, from the lowest: compounds 2, 3, 1 and 4 (each within the scatter of the next).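

In this assay the swap of cyclopropyl for cyclobutyl on this chain gives a 1.4-fold higher number from compound 3 to compound 4 (0.16 log units; within the scatter) while the swaps from the other two groups give a 1.6-fold higher number from compound 2 to compound 4 (0.20 log units; within the scatter) and a 1.0-fold higher number from compound 1 to compound 4 (0.02 log units; within the scatter). All three steps lie within the scatter, so the four-membered ring is not told apart from the three other groups at this place. No measurement shown gives a reason for these small steps. Still open, from the compounds shown here alone, is whether a different kind of group here, such as an amine, a carboxylic acid or a longer chain, would give a step beyond the scatter.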